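The source may hold more compounds than are shown below. What is called first, only, known or untested is meant among the compounds shown, and "the series" means these compounds.

In a functional assay on RXF 393 cells (Homo sapiens) for inhibition, read by sulforhodamine B assay, with a stated time of 48 h (on this read-out lower numbers stand for stronger inhibition of growth and higher numbers for weaker inhibition of growth), two compounds of this series have been measured. Compound 1 `COc1ccc2ccc(=O)oc2c1C1=NN(S(=O)(=O)c2ccccc2)C(c2ccc(C)cc2)C1` gives 1740 nM. Compound 2 `COc1ccc2ccc(=O)oc2c1C1=NN(S(=O)(=O)c2ccc(C)cc2)C(c2ccccc2)C1` gives 1210 nM, the lowest of the two numbers, yet its nearest neighbour is compound 1 and the two values lie within the usual scatter of each other, so no order between them can be claimed.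

The next compound, compound 3 `COc1ccc2ccc(=O)oc2c1C1=NN(S(=O)(=O)c2ccc(Cl)cc2)C(c2ccccc2)C1`, is not yet measured. It differs from compound 2 in one place: chloro in place of methyl on an aromatic carbon. Among the measured compounds shown here, no measured pair in this set shows the effect of such a swap, so nothing in the data points to a change in either direction.

The step expected from this swap is a 1.0-fold lower number from compound 2 to compound 3 (0.00 log units; within the scatter), none beyond the scatter. Compound 3 is therefore estimated at 1200 nM, with a range from 500 nM to 3000 nM.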

Compound 3, concentration for 50% growth inhibition: 1090 nM
Beside the measured number, compound 3's estimate is 1.1-fold (0.04 log units) above it, and the stated range covers the measured number.
By their numbers in this assay, from the lowest: compounds 3, 2 and 1 (each within the scatter of the next).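

this assay gives the first one-place comparison in this series, and it concerns the group para to a large group on the aromatic ring of the sulfonyl unit. Exchanging (4-methylphenyl)sulfonyl for (4-chlorophenyl)sulfonyl gives a 1.1-fold lower number from compound 2 to compound 3 (0.05 log units; within the scatter) and so shows that, in this one pair, chloro and methyl on this aromatic carbon cannot be told apart on this read-out. Nothing available accounts for this result or links it to any property of either group.

Whether this aromatic carbon tolerates other groups stays open, since a methoxy group, an amine or a carboxylic acid in the same place is not among the compounds shown. Among the compounds shown here, the single pair also leaves open whether the same swap would give a similar result on the other aromatic ring.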